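Chloro on the phenol ring of compound 2

The source may hold more compounds than are shown below. What is called first, only, known or untested is meant among the compounds shown, and "the series" means these compounds.

The series is built on a single core, a pyridyl ketone of a phenol, and is followed in a functional assay on HeLa cells (Homo sapiens) for cytotoxicity, read by sulforhodamine B assay, with a stated time of 48 h; a higher number here means a weaker inhibitor, a lower number a stronger inhibitor. Compound 1 `C=CCOc1ccc(F)cc1C(=O)c1cccnc1`, carrying an allyloxy group and fluorine, gives 93000 nM. Compound 2 `O=C(c1cccnc1)c1ccccc1O`, the bare phenol, gives 33000 nM, the lowest of the three numbers shown; its bromo analogue, compound 3 `O=C(c1cccnc1)c1ccc(Br)cc1O`, gives 37000 nM and sits within the scatter of compound 2, while compound 1 is beyond the scatter on the higher side.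

Compound 4 `O=C(c1cccnc1)c1cccc(Cl)c1O` has not yet been measured. It differs from compound 2 in one place: chloro in place of hydrogen on an aromatic carbon.

For the measured compounds named here, the only measured step that bears on this is the one-place change a 1.1-fold higher number from compound 2 to compound 3 (0.05 log units; within the scatter), a halogen entering the same ring at a different place. That step stayed within the scatter, and nothing else in the data separates chloro from bromo or the new place from the old. For compound 4 the expectation is therefore no step beyond the scatter, with the step from compound 2 to compound 4 estimated at a 1.1-fold higher number from compound 2 to compound 4 (0.03 log units; within the scatter). Compound 4 is expected to give about 35000 nM in this assay, with a likely range from 15000 nM to 85000 nM.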

Compound 4, half-maximal inhibitory concentration: 21000 nM
Compound 4: the middle estimate sits 1.7-fold (0.22 log units) above what was measured, and the stated range covers the measured number.
By their numbers in this assay, from the lowest: compounds 4, 2 and 3 (each within the scatter of the next); then compound 1.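

In this assay, chloro on an aromatic carbon ortho to a hydroxy group gives no step beyond the scatter: a 1.6-fold lower number from compound 2 to compound 4 (0.20 log units; within the scatter). This gives the series a reading at a second place on the phenol ring, and alongside a 1.1-fold higher number from compound 2 to compound 3 (0.05 log units; within the scatter) it shows two single halogen changes to compound 2, at different places, with neither step leaving the scatter. The data shown contain no independent measurement that could account for the size of this step.

Still open, on these data alone, is whether this carbon responds to anything other than a halogen, which an amine, a carboxylic acid or a longer chain such as propoxy at the same place would begin to test. Also open, as far as these compounds go, is the separate contribution of the allyloxy group and the fluorine of compound 1, since compound 1 differs from compound 2 in more than one place and no single change connects them.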